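Benzamidomethyl in place of 4-(tert-butoxy)phenyl

The compounds below may be only part of what the source reports. "The series", "measured", "known", "first", "only" and "open" are said of these compounds alone.

Measured in a functional assay on A-431 cells (Homo sapiens) for inhibition, read by MTT assay, with a stated time of 72 h; on this read-out higher numbers stand for weaker inhibition and lower numbers for stronger inhibition:
- compound 1 `Cc1ccc(-c2nnc(SCCCN3CCN(c4nc5ccccc5o4)CC3)o2)cc1`: 100000 nM
- compound 2 `Fc1ccc(-c2nnc(SCCCN3CCN(c4nc5ccccc5o4)CC3)o2)cc1`: 136000 nM
- compound 3 `CC(C)(C)Oc1ccc(-c2nnc(SCCCN3CCN(c4nc5ccccc5o4)CC3)o2)cc1`: 65800 nM

Compound 3, at 65800 nM, sits within the scatter of compound 1 and a modest step under compound 2. The next compound is compound 4 `O=C(NCc1nnc(SCCCN2CCN(c3nc4ccccc4o3)CC2)o1)c1ccccc1`, with benzamidomethyl in place of 4-(tert-butoxy)phenyl on an aromatic carbon. Among the measured compounds shown here, no measured compound carries benzamidomethyl, so the measured steps bear on this change only loosely. Each of them exchanges one small group on an aromatic carbon, not the whole 4-(tert-butoxy)phenyl group. They are a 1.4-fold higher number from compound 1 to compound 2 (0.13 log units; within the scatter), a 1.5-fold lower number from compound 1 to compound 3 (0.18 log units; within the scatter) and a 2.1-fold lower number from compound 2 to compound 3 (0.32 log units; beyond the scatter). The first two lie within the scatter and the third only just beyond it. On that basis no step beyond the scatter is expected in this assay, with a slight lean towards the level of compound 1 at 100000 nM. The estimated step is a 1.4-fold higher number from compound 3 to compound 4 (0.14 log units; within the scatter). Compound 4 is estimated at 90000 nM, with an expected range of 40000 nM to 200000 nM.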

Compound 4, half-maximal inhibitory concentration: 36900 nM
Beside the measured number, compound 4's estimate is 2.4-fold (0.39 log units) above it; measured number outside the range, below it.
By their numbers in this assay, from the lowest: compounds 4, 3, 1 and 2 (each within the scatter of the next, the first and the last beyond it).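

At the position on the five-membered aromatic ring with 2 nitrogen and 1 oxygen, this assay tolerates the exchange of a directly attached substituted phenyl for benzamidomethyl, which brings 1 hydrogen-bond donor: the step is a 1.8-fold lower number from compound 3 to compound 4 (0.25 log units; within the scatter). Against the two smaller aryl groups the same exchange passes beyond the scatter, modestly, with a 3.7-fold lower number from compound 2 to compound 4 (0.57 log units; beyond the scatter) and a 2.7-fold lower number from compound 1 to compound 4 (0.43 log units; beyond the scatter), so this position accepts more than the para-free small-group changes on the phenyl ring had tested. No evidence is available to explain these steps.

Still open, from the compounds shown here alone, is whether the amide hydrogen, the carbonyl or the methylene link accounts for the steps, and an N-methyl amide or a longer chain in place of the methylene would separate these. Also open, going by these compounds, is whether an amine or a carboxylic acid on the benzamide ring moves compound 4, at 36900 nM, any further.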